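Thiazole Substituent Changes and Efficacy at Free Fatty Acid Receptor 2

This account rests on a few compounds, and the source may have more. Where it says the series, first, only, none or still open, it means among the compounds named here.

Measured compounds:
compound 1 `CC(C)(C)[C@H](C(=O)Nc1ncc(Br)s1)c1ccc(Cl)cc1`: 95%
compound 2 `CC(C)(C)[C@H](C(=O)Nc1ncc(C(F)(F)F)s1)c1ccc(Cl)cc1`: 95%
compound 3 `CSc1cnc(NC(=O)[C@H](c2ccc(Cl)cc2)C(C)(C)C)s1`: 109%

In a functional assay on CHO cells for agonist activity at Free fatty acid receptor 2 (Homo sapiens), read by cAMP accumulation (a lower number here means a smaller maximal response, a higher number a larger maximal response), compound 3 gives the highest of the three numbers, with compound 1 a number 14 percentage points higher from compound 1 to compound 3 (beyond the scatter) and compound 2 a number 14 percentage points higher from compound 2 to compound 3 (beyond the scatter) both modestly below it. Compound 4 `CC(C)(C)[C@H](C(=O)Nc1ncc(Cc2ccc(Cl)cc2)s1)c1ccc(Cl)cc1` has not been measured; it differs from compound 3 by 4-chlorobenzyl in place of methylsulfanyl on an aromatic carbon. Within the data shown here, no measured step exchanges a small substituent for a group of this kind, so the two modest steps are only loosely comparable; all three measured compounds reach near-full or above-full efficacy. Compound 4 is therefore expected to stay in the same region, with an estimated step of a number 9 percentage points lower from compound 3 to compound 4 (within the scatter). The estimate for compound 4 is 100%, ranging from 80% to 115%.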

Compound 4, largest response reached (reported as efficacy), in percent of the reference or control that the assay uses: 100%
Beside the measured number, compound 4's estimate shows no gap at the digits printed, and the stated range covers the measured number.
By their numbers in this assay, from the lowest: compounds 1, 2, 4 and 3 (each within the scatter of the next, the first and the last beyond it).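

In this assay, this position next to the ring sulfur takes 4-chlorobenzyl, a group that brings a whole six-membered aromatic ring, and the maximal response stays within the scatter of all three smaller substituents (a number 9 percentage points lower from compound 3 to compound 4 (within the scatter); a number 5 percentage points higher from compound 2 to compound 4 (within the scatter); a number 5 percentage points higher from compound 1 to compound 4 (within the scatter)). Among these four compounds, then, a high maximal response does not require a small substituent here. No supporting measurement bears on why the response holds. Still open, as far as these compounds go, is how an amine, a carboxylic acid or a longer chain at this position would behave.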